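Nitrogen Inserted at the Carbonyl: Expected Growth Inhibition

The source may report more compounds than this note shows. Statements on the series, on what has been measured and on what is new or still open speak of the compounds shown alone.

Measured compounds:
compound 1 `COc1cc(-c2nn(-c3cccc(NC(=O)c4cccc(C(F)(F)F)c4)c3)cc2-c2ccncc2)ccc1Cl`, 1620 nM
compound 2 `O=C(Nc1cccc(-n2cc(-c3ccncc3)c(-c3ccc(Cl)c(O)c3)n2)c1)Nc1ccc(Cl)c(Cl)c1`, 1510 nM

Both compounds were tested in a functional assay on U-251 cells (Homo sapiens) for inhibition, read by sulforhodamine B assay, with a stated time of 48 h; on this read-out higher numbers stand for weaker inhibition of growth and lower numbers for stronger inhibition of growth. Compound 1 gives 1620 nM, and compound 2 gives 1510 nM. These two numbers lie within the scatter of each other, so compound 1 does not stand apart from compound 2 on this read-out. Going by the values given here, compound 2 differs from compound 1 in more than one place, so no single step connects them; their two values simply show that the assembly of changes between them leaves the number essentially unchanged.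

Compound 3 `COc1cc(-c2nn(-c3cccc(NC(=O)Nc4cccc(C(F)(F)F)c4)c3)cc2-c2ccncc2)ccc1Cl` is not yet measured. It differs from compound 1 by (3-(trifluoromethyl)phenyl)amino in place of 3-(trifluoromethyl)phenyl on a carbonyl carbon. Among the compounds with values here, no measured pair isolates this change, so the expectation rests only on the near-equal values of compound 1 and compound 2: the step from compound 1 to compound 3 in this assay is expected to be small, not beyond the scatter, in either direction. Compound 3 is accordingly estimated at 1300 nM, with a range from 450 nM to 3800 nM. The expected step of a 1.2-fold lower number from compound 1 to compound 3 (0.10 log units; within the scatter) is within the scatter.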

Compound 3, concentration for 50% growth inhibition: 645 nM
Estimate against measurement, compound 3: 2.0-fold (0.30 log units) above; the range from low to high includes it.
By their numbers in this assay, from the lowest: compound 3; then compounds 2 and 1 (each within the scatter of the next).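

In this assay, placing (3-(trifluoromethyl)phenyl)amino in place of 3-(trifluoromethyl)phenyl on the carbonyl carbon gives a 2.5-fold lower number from compound 1 to compound 3 (0.40 log units; beyond the scatter) and so shows that this single change moves the read-out, a modest step towards stronger inhibition of growth. The earlier pair differed in more than one place and could not isolate this change, whereas here the rest of the structure stays fixed and the step belongs to this one replacement. Nothing available explains the step.

As far as these compounds go, it remains open whether an oxygen or a methylene in the same place, giving a carbamate or a (3-(trifluoromethyl)phenyl)methyl group, would match the nitrogen. From the compounds shown here alone, it also remains open whether the same step would appear with a different group on the aromatic ring, such as a methyl or a chlorine in place of the trifluoromethyl.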